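This account rests on a few compounds, and the source may have more. Where it says the series, first, only, none or still open, it means among the compounds named here.

The compounds share one core that carries a carboxylic acid at one end and an ether chain at the other; they differ only in that chain. Compound 1, drawn as `COCCOc1cc(C)c(-c2cccc(COc3ccc(OCC(=O)O)c(F)c3)c2)c(C)c1`, carries a 2-methoxyethyl group on the aromatic oxygen, and in a physicochemical assay for lipophilicity, using the shake flask method, in phosphate buffer, measured as octanol-water partition, with a stated time of 24 h, at pH 7.4, tested at 100 uM (a lower number here means a more polar compound, a higher number a more lipophilic compound), compound 1 gives 3.15. Compound 2, drawn as `COCCCOc1cc(C)c(-c2cccc(COc3ccc(OCC(=O)O)c(F)c3)c2)c(C)c1`, carries a 3-methoxypropyl group in the same place, and for compound 2 the entry in this assay reads "not determined" (no result reported), so no number is known for it. Compound 2 therefore cannot be placed against compound 1 on the scale. Among the compounds with values here, no measured step connects any pair here.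

Compound 3, drawn as `CCCOc1cc(C)c(-c2cccc(COc3ccc(OCC(=O)O)c(F)c3)c2)c(C)c1`, is the next point. The change from compound 2 to compound 3 is hydrogen in place of methoxy on a saturated chain carbon, three bonds along the chain from an oxygen on an aromatic ring. Within the data shown here, with no measured step for guidance, the expectation rests on general experience with pairs of this kind: a shift in this assay towards a higher value, of a size clearly larger than the scatter of repeated measurements. On that basis compound 3 is expected to give about 4, with a likely range from 3.4 to 4.6.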

Compound 3, distribution coefficient: 3.64
Compound 3: the middle estimate sits 0.36 log units above what was measured; the measured number falls inside the stated range.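

Within the data shown here, with a second number on the scale, the chain on the shared core can now be read for the first time: in this assay the result is a number 0.49 log units higher from compound 1 to compound 3 (beyond the scatter). The change here is methyl in place of methoxy on a saturated chain carbon, two bonds along the chain from an oxygen on an aromatic ring, so the propyl chain stands higher on this scale than the 2-methoxyethyl chain, and swapping the end of this chain is enough to move the number past the usual scatter. This is a single step between two compounds, it sets no general rule for the chain, and nothing given here accounts for the shift.

From the compounds shown here alone, compound 2 has no number, so steps to or from it cannot be read, and where the 3-methoxypropyl chain falls relative to the other two chains stays open. Also open, going by these compounds, is how the number would respond to an amine, a hydroxyl group or a longer chain such as butyl in the same place, and whether a step of this size would recur on a different core.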